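The source may hold more compounds than are shown below. What is called first, only, known or untested is meant among the compounds shown, and "the series" means these compounds.

Of the compounds shown here, two have been measured. Compound 1 `COc1ccc(OC)c(/C=C/c2nnc(Nc3ccc(Cl)cc3)o2)c1` reaches only the limit of > 100000 nM in a functional assay on NCI-H460 cells (Homo sapiens) for antiproliferative activity, read by sulforhodamine B assay, with a stated time of 48 h (on this read-out lower numbers stand for stronger inhibition of growth and higher numbers for weaker inhibition of growth), and that figure is a limit rather than a number. Compound 2 `COc1ccc(OC)c(/C=C/C(=O)N/N=C/c2ccc(Cl)cc2)c1` has a different core, and in this assay compound 2 gives 13800 nM. Among the numbers shown, compound 2 therefore holds the only measured value, since the other entry sits at the limit of > 100000 nM in this assay, at which 1 of the 2 values shown sits. Compound 3 `COc1ccc(OC)c(/C=C/C(=O)N/N=C/c2ccccc2)c1` keeps the core of compound 2 and differs from it at the aromatic end only: hydrogen in place of chloro on an aromatic carbon. Among the compounds with values here, no step between two measured compounds is available that would show how much such a change is worth here. Removal of a single chloro group is expected to move the number in this assay only a little, toward weaker inhibition of growth if anywhere, and possibly not beyond the scatter. The step from compound 2 to compound 3 is thus estimated as a 1.6-fold higher number from compound 2 to compound 3 (0.20 log units; within the scatter). Compound 3 is accordingly expected to give 22000 nM, within a range from 7000 nM to 70000 nM.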

Compound 3, concentration for total growth inhibition: 5620 nM
Compound 3: the middle estimate sits 3.9-fold (0.59 log units) above what was measured; measured number below the stated range.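

In this assay the change from 4-chlorophenyl to phenyl brings a 2.5-fold lower number from compound 2 to compound 3 (0.39 log units; beyond the scatter) and so gives this series its first measured step, one that points toward stronger inhibition of growth and lies beyond the scatter. On this core, in this one pair, the chloro group on an aromatic carbon para to a large group is therefore not needed for the activity read here, and hydrogen in its place gives the lower number. Nothing among the measurements shown gives a cause for this step.

With only chloro and hydrogen shown at this position, it remains open how a fluoro, a methoxy, a trifluoromethyl or an amine there would compare, and so whether the number follows any trend across groups or reflects something particular to chloro. Going by these compounds, it also remains open whether the same change would move the number on the core of compound 1, whose only entry in this assay is a limit and offers no number to compare against.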